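From acetoxy to hydroxymethyl on a sulfonyl chain

A few compounds are considered here, and "the series" means these few. Any claim that something is new, unique, unknown or untested is made for them only; others in the source may bear on it.

Of the compounds shown here, two have numbers so far. In a physicochemical assay for solubility, at pH 7.4 (a lower number here means a less soluble compound, a higher number a more soluble compound), compound 1 (`NS(=O)(=O)c1ccc(S(=O)(=O)CCCO)c(C(=O)O)c1`) gives 53000 ug/mL, and compound 2 (`CC(=O)OCCS(=O)(=O)c1ccc(S(N)(=O)=O)s1`) gives 880 ug/mL. Compound 2 therefore holds the lower of the two numbers, and its gap to compound 1 lies beyond the usual scatter of repeated measurements. These two compounds differ in more than one place, so the gap cannot be tied to any single change.

Compound 3 (`NS(=O)(=O)c1ccc(S(=O)(=O)CCCO)s1`) has not yet been measured. Compared with compound 2, its structural change is hydroxymethyl in place of acetoxy on a saturated chain carbon, two bonds along the chain from a sulfonyl sulfur. Hydroxymethyl stands in place of acetoxy on a saturated chain carbon, two bonds along the chain from a sulfonyl sulfur, which also reads as 2-acetoxyethyl to 3-hydroxypropyl. Within the data shown here, compound 1 also carries 3-hydroxypropyl and gives 53000 ug/mL, so a moderate step up in this assay, beyond the scatter, is expected, although no measured pair shows this change alone. The expected move is a 4.5-fold higher number from compound 2 to compound 3 (0.66 log units; beyond the scatter). For compound 3 the estimated value is 4000 ug/mL, with an expected range of 1400 ug/mL to 12000 ug/mL.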

Compound 3, solubility: 14600 ug/mL
Compound 3: the middle estimate sits 3.7-fold (0.56 log units) below what was measured; the measured number lies above the stated range.
By their numbers in this assay, from the lowest: compound 2; then compound 3; then compound 1.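

Among these compounds, this is the first pair here that differs in one place only, so in this assay a change can now be tied to a single site. Hydroxymethyl in place of acetoxy on a saturated chain carbon, two bonds along the chain from a sulfonyl sulfur, gives a 17-fold higher number from compound 2 to compound 3 (1.22 log units; beyond the scatter), a large step beyond the usual scatter, which shows that the group in this place can move the number a long way while the rest of the compound stays the same. No measurement available here bears on why the number moves, so the step stands as an observation without an explanation.

Acetoxy and hydroxymethyl differ in several ways at once, including the hydrogen-bond donor that enters and the double bond that leaves, and this one pair cannot separate those differences. As far as these compounds go, it also remains open whether a methoxy group, an amine or a longer chain carrying a hydroxyl group in this place would give a similar number, and whether the same swap would give a step of similar size on the core of compound 1.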